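The source may report more compounds than this note shows. Statements on the series, on what has been measured and on what is new or still open speak of the compounds shown alone.

Measured in an ADME assay on Vero cells (Chlorocebus sabaeus) for cytotoxicity, read by neutral red uptake, with a stated time of 48 h; on this read-out higher numbers stand for weaker inhibition and lower numbers for stronger inhibition:
Compound 1 `CCN(CC)c1nc(Cl)nc2c1ncn2CCNc1ccnc2cc(Cl)ccc12`: > 11000 nM (a limit)
Compound 2 `Clc1ccc2c(NCCn3cnc4c(N5CCCC5)nc(Cl)nc43)ccnc2c1`: > 11100 nM (a limit)
Compound 3 `CCN(CC)c1nc(Cl)nc2c1ncn2CCCNc1ccnc2cc(Cl)ccc12`: > 10700 nM (a limit)

Compound 3 sits at > 10700 nM and this is a limit of the assay, not a number. The other two compounds also give only limits, so no measured number is available for comparison with compound 3.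

The change to compound 4 `Clc1ccc2c(NCCCn3cnc4c(N5CCN(c6ccccc6)CC5)nc(Cl)nc43)ccnc2c1` lies in a single group: 4-phenylpiperazin-1-yl in place of diethylamino on an aromatic carbon and the rest of the structure stays as in compound 3. Among the compounds with values here, only one measured step bears on this, the exchange of the same diethylamino group for pyrrolidin-1-yl: a step that the two limits leave unreadable from compound 1 to compound 2 offers no size to carry over. The entering 4-phenylpiperazin-1-yl is also a different group from pyrrolidin-1-yl, so even that step would be a loose guide.

The data in this assay therefore support no expectation of a step beyond the scatter, and they favour no direction. The expected step is an at least 1.1-fold lower number from compound 3 to compound 4 (0.05 log units; that floor lies within the scatter) and it rests mainly on all three measured compounds sitting at similar limits. For compound 4 the estimated value is 9500 nM with an expected range from 4000 nM to 12000 nM and the assay may well report only a limit again.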

Compound 4, half-maximal inhibitory concentration: > 8900 nM
Compound 4 ended at the assay's limit; the forecaster's own chance of this, stated with the estimate: 70%; the middle value does not contradict the limit.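

In this assay compound 3 gives > 10700 nM, which is a limit and not a number. Compound 4 gives > 8900 nM, also a limit. Within the data shown here, no step from compound 3 to compound 4 can be read from these two limits. The compounds shown leave open where any of their half-maximal inhibitory concentrations actually lies, and whether 4-phenylpiperazin-1-yl in place of diethylamino shifts it at all.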